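Adding a Methyl to the Chain of Compound 1

A few compounds are considered here, and "the series" means these few. Any claim that something is new, unique, unknown or untested is made for them only; others in the source may bear on it.

Measured compounds:
compound 1, `CC1=C(CCC(=O)OCCCCOc2no[n+]([O-])c2S(=O)(=O)c2ccccc2)C(=O)c2c(O)cccc2C1=O`, 8310 nM
compound 2, `CC1=C(CCCC(=O)OCCOc2no[n+]([O-])c2S(=O)(=O)c2ccccc2)C(=O)c2c(O)cccc2C1=O`, 10300 nM

In a functional assay on A549 cells (Homo sapiens) for inhibition, read by MTT assay, with a stated time of 72 h (a lower number here means a stronger inhibitor, a higher number a weaker inhibitor), compound 1 gives 8310 nM, and compound 2 gives 10300 nM; the two numbers lie within the usual scatter of each other, so neither stands apart. Compound 3, `CC1=C(C(C)CC(=O)OCCCCOc2no[n+]([O-])c2S(=O)(=O)c2ccccc2)C(=O)c2c(O)cccc2C1=O`, has not been measured. It differs from compound 1 by methyl in place of hydrogen on a saturated chain carbon bound to a double-bonded ring carbon and a saturated chain carbon. Going by the values given here, no measured pair shows what such a change does here, so the expected step of a 1.1-fold higher number from compound 1 to compound 3 (0.03 log units; within the scatter) is small, in no clear direction and not beyond the scatter. Compound 3 is therefore expected to give about 9000 nM, within 3000 nM to 27000 nM.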

Compound 3, half-maximal inhibitory concentration: 19600 nM
The estimate for compound 3 lay 2.2-fold (0.34 log units) below the measured number, and the stated range covers the measured number.
By their numbers in this assay, from the lowest: compounds 1, 2 and 3 (each within the scatter of the next, the first and the last beyond it).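

In this assay the swap of hydrogen for methyl on this saturated chain carbon gives a 2.4-fold higher number from compound 1 to compound 3 (0.37 log units; beyond the scatter) and so a modestly weaker inhibitor. Going by these compounds alone, this shows that the carbon is not indifferent to substitution, which the earlier compounds could not show, as neither carries a methyl on its chain. Nothing measured here explains the loss. Still open, going by these compounds, is whether an ethyl, a hydroxyl or an amine on this carbon would weaken inhibition further, and whether the same methyl would have a similar effect on the chain of compound 2.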